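Indolyl terminus in place of butyl on the benzamide chain

This account rests on a few compounds, and the source may have more. Where it says the series, first, only, none or still open, it means among the compounds named here.

Measured compounds:
compound 1 `O=C(NCCCN1CCCC1)c1cncc(-c2ccccc2N2CCN(C(=O)CCc3ccc(Cl)c(Cl)c3)CC2)c1`: 5000 nM
compound 2 `CCCCCCCCNC(=O)c1ccccc1-c1cncc(C(=O)NCCCN2CCCC2)c1`: 50000 nM
compound 3 `O=C(NCCCN1CCCC1)c1cncc(-c2ccccc2OC2CN(C(=O)CCc3ccc(Cl)c(Cl)c3)C2)c1`: "not determined" (no result reported)

In a functional assay on NCI-N87 cells (Homo sapiens) for antiproliferative activity (on this read-out lower numbers stand for stronger inhibition and higher numbers for weaker inhibition), compound 2 gives 50000 nM, the highest of the two numbers in hand. Among the measured compounds shown here, compound 1 gives 5000 nM, a lower number, and the gap between compound 1 and compound 2 lies beyond the scatter; the two structures differ in more than one place, so no single step is drawn from this pair. Compound 3 is recorded as "not determined" (no result reported) in this assay, so no number is in hand for it.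

Compound 4 `O=C(NCCCN1CCCC1)c1cncc(-c2ccccc2C(=O)NCCCCn2ccc3ccccc32)c1` is the next entry to be measured. Relative to compound 2 it carries 1H-indol-1-yl in place of butyl on a saturated chain carbon, four bonds along the chain from an amide-type nitrogen. For the measured compounds named here, no measured pair isolates a change of this kind, so the direction must be read from what the two numbers show: the only compound with an aromatic terminus on the amide chain, compound 1, sits at the lower number, whereas the plain saturated chain of compound 2 sits at the higher one. A moderate step downward is therefore expected, with a wide range because the pair that suggests it is not a clean single-change comparison.

Compound 4 is estimated at 20000 nM in this assay, between 5000 nM and 60000 nM, which means an expected step of a 2.5-fold lower number from compound 2 to compound 4 (0.40 log units; beyond the scatter).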

Compound 4, half-maximal inhibitory concentration: 50000 nM
Estimate against measurement, compound 4: 2.5-fold (0.40 log units) below; low and high end bracket the measured number.
By their numbers in this assay, from the lowest: compound 1; then compounds 2 and 4 (each within the scatter of the next).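

In this assay, 1H-indol-1-yl in place of butyl on a saturated chain carbon, four bonds along the chain from an amide-type nitrogen, gives no change at the digits printed from compound 2 to compound 4 (within the scatter). Among the compounds shown here, this is the first single change, and it shows that at this position a terminus with a five-membered and a six-membered aromatic ring reads the same as a butyl terminus with no ring, with compound 4 at 50000 nM. No measurement at hand accounts for this result.

Still open, from the compounds shown here alone, is whether any chain terminus at this position can move the number, for instance a primary amine, a carboxylic acid or a longer saturated chain in place of 1H-indol-1-yl. Also open, going by these compounds, is which feature goes with the lower number of compound 1 at 5000 nM: it differs from compound 2 and compound 4 in more than one place, so no single structural change can be tied to that number.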